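A Second Methyl on the Shared Core and Lipophilicity

The source may report more compounds than this note shows. Statements on the series, on what has been measured and on what is new or still open speak of the compounds shown alone.

Of the compounds shown here, three have been measured in a physicochemical assay for lipophilicity; a lower number here means a more polar compound, a higher number a more lipophilic compound. Compound 1 `COc1c(OC)c(OC(C)=O)c2ccccc2c1OC(C)=O` gives 2.39. Compound 2 `COc1c(OC)c(OC(C)=O)c2cc(C)ccc2c1OC(C)=O` carries one additional group, and in this assay compound 2 gives 2.86. The change between them is methyl in place of hydrogen on an aromatic carbon. The step it made was a number 0.47 log units higher from compound 1 to compound 2 (beyond the scatter).

Compound 3 `COc1c(OC)c(OC(=O)C(C)(C)C)c2cc(C)ccc2c1OC(=O)C(C)(C)C` has a different core; the difference between the core of compound 1 and the core of compound 3 is not broken down here. In this assay compound 3 gives 6.1, the highest of the three numbers, beyond the scatter from both others.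

Compound 4 `COc1c(OC)c(OC(=O)C(C)(C)C)c2cc(C)c(C)cc2c1OC(=O)C(C)(C)C` is not yet measured. It differs from compound 3 by methyl in place of hydrogen on an aromatic carbon. For the measured compounds named here, this is the same kind of change as the one from compound 1 to compound 2, but not the same: here the entering group sits ortho to a methyl group (1 heavy atom), which the earlier place did not have.

Going by the values given here, a step of similar size is expected, a number 0.45 log units higher from compound 3 to compound 4 (beyond the scatter), because the one measured example of this kind of change gave a number 0.47 log units higher from compound 1 to compound 2 (beyond the scatter). For compound 4 the estimated result in this assay is 6.55, likely lying between 6.1 and 7.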

Compound 4, partition coefficient: 6.5
Compound 4: the middle estimate sits 0.05 log units above what was measured, within the range that was stated.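

In this assay the change carries over to the second core: the step is a number 0.40 log units higher from compound 3 to compound 4 (beyond the scatter) and the earlier one was a number 0.47 log units higher from compound 1 to compound 2 (beyond the scatter) so both pairs show a modest rise when methyl takes the place of hydrogen on an aromatic carbon, and neither goes against the other, even though the new methyl here sits ortho to a methyl group. This supports using the measured step as a guide between these two cores, but two pairs do not make a general rule, and they show nothing about other places on the ring system or about cores beyond these. No measurement here explains why the step carries over.

The compounds shown leave open what would happen if this same hydrogen gave way to a different group, such as an amine, a carboxylic acid or a longer chain. They also leave open whether a third methyl on an aromatic carbon would add a similar step.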